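The source may report more compounds than this note shows. Statements on the series, on what has been measured and on what is new or still open speak of the compounds shown alone.

Notes on the series in an assay on NK92 cells for inhibition of interleukin-2 (Homo sapiens), read by AlphaScreen, with stated times of 30 min and 1 h; on this read-out lower numbers stand for stronger inhibition and higher numbers for weaker inhibition. Compound 1 `CCOC(CCn1c(Cc2nn(C)c(=O)c3ccccc23)nnc1SCCCCCCCC(=O)Nc1ccc(Cl)cc1Cl)OCC` gives only a limit of the assay, > 30000 nM. Compound 2 `CN(C)CCCn1c(Cc2nn(C)c(=O)c3ccccc23)nnc1SCCCCCCCC(=O)Nc1ccc(Cl)cc1Cl` likewise reaches only a limit, > 30000 nM. Compound 3 `Cn1nc(Cc2nnc(SCCCCCCCC(=O)Nc3ccc(Cl)cc3Cl)n2CCCO)c2ccccc2c1=O` also stands at a limit, > 30000 nM. The steps a step that the two limits leave unreadable from compound 1 to compound 2, a step that the two limits leave unreadable from compound 1 to compound 3 and a step that the two limits leave unreadable from compound 2 to compound 3 cannot be sized, since (the limit of > 30000 nM in this assay, at which 3 of the 3 values shown sit). Compound 4 `Cn1nc(Cc2nnc(SCCCCCCCC(=O)Nc3ccc(Cl)cc3Cl)n2CCC(=O)O)c2ccccc2c1=O` differs from compound 3 by carboxy in place of hydroxymethyl on a saturated chain carbon, two bonds along the chain from an aromatic nitrogen. Among the compounds with values here, with none of the measured steps readable, no change beyond the scatter can be anticipated in either direction for the step from compound 3 to compound 4, and a further limit is the likeliest outcome. Compound 4 is therefore expected near 30000 nM, in the range 10000 nM to 100000 nM. The expected step is a number no higher from compound 3 to compound 4 (the limit leaves the size open).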

Compound 4, half-maximal inhibitory concentration: 14300 nM
Compound 4: middle estimate off by 2.1-fold (0.32 log units), on the high side; low and high end bracket the measured number.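

Carboxy, on a saturated chain carbon two bonds along the chain from an aromatic nitrogen, is the first group here to bring the series off the limit: the limit of > 30000 nM in this assay, at which 3 of the 4 values shown sit. The compounds give an at least 2.0-fold lower number from compound 3 to compound 4 (0.32 log units; beyond the scatter) and an at least 2.0-fold lower number from compound 2 to compound 4 (0.32 log units; beyond the scatter) and also an at least 2.0-fold lower number from compound 1 to compound 4 (0.32 log units; beyond the scatter) as minimum sizes only. Going by these compounds, the change therefore shows that this position can affect the read-out, though the true size of each step stays unknown.

Open, on these data alone, is how a methyl ester or primary amide would read here, and whether carboxymethyl or a longer carboxy-bearing chain would lower the number further.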